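The source may report more compounds than this note shows. Statements on the series, on what has been measured and on what is new or still open speak of the compounds shown alone.

Compound 1 `O=CN1N=C(c2ccc(F)cc2)CC1c1cn(-c2ccccc2)nc1-c1ccc(Cl)c(Cl)c1` gives 60.9% in a functional assay on the whole organism (strain Wistar) for inhibition, with Rattus norvegicus as the target, read by paw edema, with stated times of 30 min and 120 min, at a dose of 50 mg/kg by the oral route; a lower number here means less inhibition, a higher number more inhibition at the dose given (going by the name of the read-out).
Compound 2 `O=CN1N=C(c2ccc(Cl)cc2)CC1c1cn(-c2ccccc2)nc1-c1ccc(Cl)c(Cl)c1` gives 57.8%.

Among the measured compounds shown here, compound 2 carries the lower of the two numbers, but the only measured step, a number 3.1 percentage points lower from compound 1 to compound 2 (within the scatter), keeps the two within the scatter, so no order between them can be read. Compound 3 `Clc1ccc(C2=NN(c3ccccc3)C(c3cn(-c4ccccc4)nc3-c3ccc(Cl)c(Cl)c3)C2)cc1` differs from compound 2 in a single place: phenyl in place of formyl on an amine nitrogen in a ring. For the measured compounds named here, no measured step bears on this change; the one step available concerns chloro in place of fluoro on an aromatic carbon, which is a different group at a different place, and it was itself within the scatter. With nothing to guide a direction, compound 3 is expected to stay close to compound 2, because 57.8% is the only anchor, and the estimated step of a number 0.2 percentage points higher from compound 2 to compound 3 (within the scatter) is therefore expected to be none beyond the scatter. Compound 3 is estimated at 58%, within a range from 40% to 75%.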

Compound 3, a percentage reported as inhibition, in the whole organism at one dose (the size of the read-out at that dose, not a potency): 61.7%
Estimate against measurement, compound 3: 3.7 percentage points below; the range from low to high includes it.
By their numbers in this assay, from the lowest: compounds 2, 1 and 3 (each within the scatter of the next).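

On the amine nitrogen in the ring, the change from formyl to phenyl gives a number 3.9 percentage points higher from compound 2 to compound 3 (within the scatter) in this assay. Among the compounds shown here, the first measured change at this position therefore shows that a much larger group, carrying a six-membered aromatic ring of carbon only and no hydrogen-bond acceptor, can replace formyl with no difference that can be told from the scatter, so the formyl is not required for the inhibition seen at this dose in these two compounds. No evidence here accounts for this result.

The compounds shown leave open how a methyl, an acetyl or a carboxylic acid on this nitrogen would read. They also leave open whether phenyl and formyl would still read alike with the 4-fluorophenyl group of compound 1 in place of the 4-chlorophenyl group.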